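The compounds below may be only part of what the source reports. "The series", "measured", "known", "first", "only" and "open" are said of these compounds alone.

Three compounds sharing one core have been run in a functional assay on HEK293 cells for antagonist activity at Voltage-dependent L-type calcium channel subunit alpha-1D (Rattus norvegicus), read by FLIPR; on this read-out higher numbers stand for weaker inhibition and lower numbers for stronger inhibition. Compound 1 `CCOC(=O)C1=C(C)NC(COC)=C(C(=O)OC)C1c1cccc([N+](=O)[O-])c1` gives 96 nM, compound 2 `CCOC(=O)C1=C(C)NC(/C=C/c2ccc([N+](=O)[O-])cc2)=C(C(=O)OCC)C1c1cccc([N+](=O)[O-])c1` gives 2060 nM, and compound 3 `C#CCCOC(=O)C1=C(C)NC(C)=C(C(=O)OC)C1c1cccc([N+](=O)[O-])c1` gives 35 nM. Compound 3 holds the lowest number of the three: compound 1 lies higher by a step beyond the scatter, and compound 2 lies higher still, far beyond it. Compound 4 `COC(=O)C1=C(C)NC(C)=C(C(=O)OCCCOc2ccccc2)C1c1cccc([N+](=O)[O-])c1` is not yet measured; it differs from compound 3 by phenoxymethyl in place of ethynyl on a saturated chain carbon, two bonds along the chain from an oxygen next to a carbonyl group. Among the measured compounds shown here, no measured pair shows this change directly. Compound 1 gives 96 nM and compound 3 gives 35 nM, so the two chain variants seen so far stay close together. The expected step of a 1.4-fold lower number from compound 3 to compound 4 (0.15 log units; within the scatter) is therefore small, within the scatter. Compound 4 is estimated at 25 nM, with a range of 8 nM to 80 nM.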

Compound 4, half-maximal inhibitory concentration: 11 nM
Compound 4: the middle estimate sits 2.3-fold (0.36 log units) above what was measured, and the stated range covers the measured number.
By their numbers in this assay, from the lowest: compound 4; then compound 3; then compound 1; then compound 2.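

In this assay, phenoxymethyl in place of ethynyl on this saturated chain carbon gives a 3.2-fold lower number from compound 3 to compound 4 (0.50 log units; beyond the scatter). This position therefore accepts a much larger group, one carrying a six-membered aromatic ring of carbon only, with no loss of inhibition. No measurement on hand accounts for the step.

The compounds shown cannot separate the aromatic ring, the ether oxygen and the chain length as the source of the step. A 4-phenylbutyl chain in the same place, or a chain ending in an amine, would bear on that question.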